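This account rests on a few compounds, and the source may have more. Where it says the series, first, only, none or still open, it means among the compounds named here.

Two measured compounds set the scene in an assay for inhibition of steroid 17-alpha-hydroxylase/17,20 lyase (Homo sapiens), tested at 2 uM; on this read-out lower numbers stand for a weaker effect and higher numbers for a stronger effect at the one concentration tested. Compound 1 `COc1ccc2cc(-c3ccc(F)cc3)ccc2c1-c1cccnc1` gives 7% in this assay, while compound 2 `Fc1ccc(-c2ccc3c(Cn4ccnc4)cccc3c2)cc1` gives 19%. Compound 2 therefore stands highest of the two numbers, and its nearest neighbour, compound 1, lies a distance below it that is beyond the usual scatter. These two compounds differ in more than one place, so the pair shows only its two values and no single step can be read from them.

Compound 3 `COc1ccc2cc(-c3ccc(F)cc3)ccc2c1Cn1ccnc1` is compound 2 with one change: methoxy in place of hydrogen on an aromatic carbon. Among the measured compounds shown here, no measured pair isolates this change, since compound 1 carries the methoxy together with a different group. The step of a number 4 percentage points lower from compound 2 to compound 3 (within the scatter) is expected to be small, a slight fall or nothing beyond the scatter. Compound 3 is estimated at 15%, with a range from 3% to 35%.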

Compound 3, a percentage reported as inhibition, at one concentration (the size of the read-out at that concentration, not a potency): 45%
Compound 3: middle estimate off by 30 percentage points, on the low side, and the stated range ends below it.
By their numbers in this assay, from the lowest: compound 1; then compound 2; then compound 3.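

In this assay, among the compounds shown here, methoxy in place of hydrogen on the aromatic carbon ortho to the (1H-imidazol-1-yl)methyl group gives the first single change that can be read, and a number 26 percentage points higher from compound 2 to compound 3 (beyond the scatter) shows that this position responds to substitution. With the methoxy kept in place, swapping pyridin-3-yl for (1H-imidazol-1-yl)methyl also counts, as a number 38 percentage points higher from compound 1 to compound 3 (beyond the scatter) shows, so the two groups are not interchangeable on this core. No measurement here offers an explanation for either step.

Still open, going by these compounds, is whether the rise is particular to methoxy or would also appear with a hydroxyl group, an ethoxy group or a chlorine atom on the same carbon. Also open, on these data alone, is whether methoxy would have a similar effect elsewhere on this ring.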